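Ethyl Ester Replacing Acetyl on a Shared Core

A few compounds are considered here, and "the series" means these few. Any claim that something is new, unique, unknown or untested is made for them only; others in the source may bear on it.

Compound 1 `COc1cc(-c2ccnc3cc(-c4ccc(C)cc4)nn23)cc(OC)c1OC` and compound 2 `COc1cc(-c2ccnc3cc(-c4ccc(C(C)=O)cc4)nn23)cc(OC)c1OC` share one core and differ only in one group on an aromatic carbon. In a functional assay on B16-F0 cells (Mus musculus) for inhibition, read by CCK-8 assay, with a stated time of 48 h (on this read-out lower numbers stand for stronger inhibition and higher numbers for weaker inhibition), compound 1 gives 21 nM, while compound 2 gives 3930 nM. The step of a 190-fold higher number from compound 1 to compound 2 (2.27 log units; beyond the scatter) shows how strongly this position can move the number. Within the data shown here, of the two numbers measured so far, compound 2 stands highest, meaning its inhibition is the weaker. Compound 3 `CCOC(=O)c1ccc(-c2cc3nccc(-c4cc(OC)c(OC)c(OC)c4)n3n2)cc1` arises from compound 2 through the change (ethoxy in place of methyl on a carbonyl carbon). Among the measured compounds shown here, no measured step covers this change itself; the only known step, a 190-fold higher number from compound 1 to compound 2 (2.27 log units; beyond the scatter), concerns methyl going to acetyl, one bond further in. The carbonyl of compound 2 is kept in compound 3, and the step of a 1.1-fold lower number from compound 2 to compound 3 (0.05 log units; within the scatter) is expected to lie within the scatter. Compound 3 is therefore estimated at 3500 nM, in a range from 900 nM to 14000 nM.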

Compound 3, half-maximal inhibitory concentration: > 10000 nM
Compound 3 ended at the assay's limit; the forecaster's own chance of this, stated with the estimate: 10%; at least 2.8-fold (0.45 log units) between middle value and limit.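

In this assay, compound 3 ends at a limit and not at a number: the limit of > 10000 nM in this assay, at which 1 of the 3 values shown sits. Even with the carbonyl kept, replacing its methyl with ethoxy gives an at least 2.5-fold higher number from compound 2 to compound 3 (0.40 log units; beyond the scatter), so the group on the carbonyl carbon also moves the result, not only the presence of a carbonyl. The full change on the aromatic carbon gives an at least 470-fold higher number from compound 1 to compound 3 (2.67 log units; beyond the scatter), and among these three compounds, both groups containing a carbonyl give much weaker inhibition than the methyl, with none going against this.

From the compounds shown here alone, how far compound 3 lies past its limit remains unknown. Going by these compounds, it also remains open whether an amine, a carboxylic acid or a longer alkyl chain on the same aromatic carbon would stay close to compound 1 or fall away as the carbonyl groups do.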